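A few compounds are considered here, and "the series" means these few. Any claim that something is new, unique, unknown or untested is made for them only; others in the source may bear on it.

Working notes on the shared core of compound 1 `COc1cccc(NN=C2C(Cl)=C(Cl)C(Cl)=C2Cl)c1`. In a functional assay on RPMI-8226 cells (Homo sapiens) for cytotoxicity, read by MTT assay, with a stated time of 48 h (a lower number here means a stronger inhibitor, a higher number a weaker inhibitor), compound 1 reports only the limit > 3000 nM, not a number. Compound 2 `Cc1cccc(NN=C2C(Cl)=C(Cl)C(Cl)=C2Cl)c1` gives 2000 nM in this assay. Going by the values given here, the single measured step, an at least 1.5-fold lower number from compound 1 to compound 2 (0.17 log units; that floor lies within the scatter), cannot be separated from the scatter. Compound 3 `O=C(NN=C1C(Cl)=C(Cl)C(Cl)=C1Cl)c1ccccc1` gives 600 nM in this assay, the lowest of the two numbers and beyond the scatter from compound 2. Compound 4 `CC(=O)NN=C1C(Cl)=C(Cl)C(Cl)=C1Cl` differs from compound 3 by methyl in place of phenyl on a carbonyl carbon. Among the compounds with values here, no measured step exchanges a phenyl for a methyl; the one measured step changes a substituent on an aromatic ring and does not bear on this change. Loss of the phenyl is expected to raise the number, a step of a 2.5-fold higher number from compound 3 to compound 4 (0.40 log units; beyond the scatter). Compound 4 is therefore estimated at 1500 nM, between 500 nM and 5000 nM.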

Compound 4, half-maximal inhibitory concentration: 1000 nM
Beside the measured number, compound 4's estimate is 1.5-fold (0.18 log units) above it, and the stated range covers the measured number.
By their numbers in this assay, from the lowest: compounds 3, 4 and 2 (each within the scatter of the next, the first and the last beyond it). At a limit, above all of these: compound 1.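

In this assay, going by these compounds alone, the first measured change on the carbonyl carbon, methyl in place of phenyl, gives a 1.7-fold higher number from compound 3 to compound 4 (0.22 log units; within the scatter). At this place, the loss of the aromatic ring therefore cannot be separated from the scatter, and the series shows no measurable dependence on phenyl here. No measurement shown gives a cause for this step. The compounds shown leave open whether a longer chain or an amine on the carbonyl carbon would keep the number in this range. They also leave open whether a methoxy group on the phenyl of compound 3 would shift it.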